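Adding a methoxy group next to the fluorine of compound 2

The compounds below may be only part of what the source reports. "The series", "measured", "known", "first", "only" and "open" are said of these compounds alone.

Measured compounds:
Compound 1 `COc1cc(O[C@H]2C[C@H](OC)C2)nc(-c2ccc3c(c2)CC[C@H](CCC(=O)O)O3)c1F` gives > 10000 nM in a functional assay on HEK293 cells for agonist activity at Free fatty acid receptor 1 (Homo sapiens), read by HTRF and inositol phosphate accumulation, with a stated time of 60 min; on this read-out lower numbers stand for an effect already at smaller amounts and higher numbers for an effect only at larger amounts of compound; this is a limit of the assay, not a number.
Compound 2 `O=C(O)CC[C@H]1CCc2cc(-c3cc(OC4CCC4)ccc3F)ccc2O1` gives 3600 nM in this assay.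
Compound 3 `O=C(O)CC[C@H]1CCc2cc(-c3cc(OC(F)(F)F)ccc3F)ccc2O1` gives 2100 nM in this assay.

Compound 2 stands at the highest of the two numbers shown, with compound 3 closest; the only measured single-place step, a 1.7-fold lower number from compound 2 to compound 3 (0.23 log units; within the scatter), lies within the scatter, so the two cannot be ordered. Compound 1 differs from compound 2 in more than one place, and its result sits at the limit (the limit of > 10000 nM in this assay, at which 1 of the 3 values shown sits), so it shows only that nothing was seen up to that concentration.

Compound 4 `COc1cc(OC2CCC2)cc(-c2ccc3c(c2)CC[C@H](CCC(=O)O)O3)c1F` is the unmeasured compound. It differs from compound 2 by methoxy in place of hydrogen on an aromatic carbon. No measured step touches this position of the ring; the one step shown, from a cyclobutyl to a trifluoromethyl on the ring oxygen, says nothing about a methoxy group entering elsewhere. The expectation for compound 4 must therefore rest on compound 2 alone, and the step of a 1.1-fold higher number from compound 2 to compound 4 (0.05 log units; within the scatter) is estimated as no change beyond the scatter, with a wide margin. Compound 4 is thus expected to give about 4000 nM in this assay, between 1200 nM and 12000 nM.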

Compound 4, half-maximal effective concentration: > 10000 nM
Compound 4 gave a limit, no number; the forecaster's own chance of this, stated with the estimate: 25%; middle value at least 2.5-fold (0.39 log units) from the limit.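

For the compounds shown here, the earlier compounds said nothing about the aromatic carbon ortho to a fluoro group, since the only readable step among them concerned the group on the ring oxygen. This carbon now proves sensitive to change: in this assay, methoxy in place of hydrogen produces an at least 2.7-fold higher number from compound 2 to compound 4 (0.44 log units; beyond the scatter), a step beyond the scatter, so a single methoxy here is enough to take the compound out of the range where the assay gives a number. Compound 4 stands at a limit of the assay rather than at a number, so the step has a lower bound but no known full size: the limit of > 10000 nM in this assay, at which 2 of the 4 values shown sit.

The compounds shown hold only hydrogen or methoxy at this carbon, so it stays open whether a smaller group such as a chlorine, or a different one such as a hydroxyl or an amine, would leave the number in place or raise it as well. As far as these compounds go, it is also open whether methoxy at this carbon would produce a similar step with the trifluoromethyl group of compound 3 on the ring oxygen in place of the cyclobutyl group.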